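The source may hold more compounds than are shown below. What is called first, only, known or untested is meant among the compounds shown, and "the series" means these compounds.

For the measured compounds named here, compound 1 `Cc1nccnc1C1CN2CCC1CC2` is the first of the two measured compounds. In a functional assay on A9L-m1 cells with A9 (Mus musculus) as the target (a higher number here means a larger maximal response, a lower number a smaller maximal response), compound 1 gives 4%. Compound 2 `COc1nccnc1C1CN2CCC1CC2` carries a methoxy in place of the methyl on an aromatic carbon, and in this assay compound 2 gives 1%. The step of a number 3 percentage points lower from compound 1 to compound 2 (within the scatter) lies within the usual scatter of such measurements. Going by the values given here, of the two numbers measured so far, compound 2 holds the lower one, yet the two values cannot truly be told apart. Compound 3 `CCOc1nccnc1C1CN2CCC1CC2` differs from compound 2 by methyl in place of hydrogen on a saturated chain carbon bound to an oxygen on an aromatic ring, so the methoxy becomes an ethoxy. Among the compounds with values here, the only measured step that bears on this change is the methyl-to-methoxy step at the same aromatic carbon, and it brought no change beyond the scatter. The step of a number 1 percentage points higher from compound 2 to compound 3 (within the scatter) is expected to stay within the scatter as well, since both measured numbers are small. Compound 3 is therefore estimated to give 2% in this assay, with a range from 0% to 10%.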

Compound 3, largest response reached (reported as maximum), in percent of the reference or control that the assay uses: 1%
Beside the measured number, compound 3's estimate is 1 percentage points above it, and the stated range covers the measured number.
By their numbers in this assay, from the lowest: compounds 2, 3 and 1 (each within the scatter of the next).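

In this assay, extending the methoxy to an ethoxy gives no change at the digits printed from compound 2 to compound 3 (within the scatter) and putting ethoxy in place of methyl on the aromatic carbon gives a number 3 percentage points lower from compound 1 to compound 3 (within the scatter) in this read-out. The methyl added on the saturated chain carbon bound to the oxygen therefore makes no difference that can be read, and methyl, methoxy and ethoxy on this aromatic carbon cannot be told apart, with all three compounds staying at small maximal responses. Nothing available explains this result. On these data alone, a longer chain on the oxygen, such as butoxy, remains open, as does the question of whether any such chain could lift the response clear of the scatter. Also open, as far as these compounds go, is what an amine or a carboxylic acid on this aromatic carbon would give.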